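A few compounds are considered here, and "the series" means these few. Any claim that something is new, unique, unknown or untested is made for them only; others in the source may bear on it.

Values so far in a physicochemical assay for lipophilicity, measured as octanol-water partition (on this read-out higher numbers stand for higher lipophilicity and lower numbers for lower lipophilicity), stand as follows

Compound 1 (`COc1ccc(/C=C/C(=O)N[C@@H]2O[C@H](CO)[C@@H](O)[C@H](O)[C@H]2O)c(O)c1`) gives -0.958
Compound 2 (`CC(C)c1ccc(/C=C/C(=O)N[C@@H]2O[C@H](CO)[C@@H](O)[C@H](O)[C@H]2O)cc1`) gives 0.296
Compound 3 (`Cc1ccc2c(c1)C=C(C(=O)N[C@@H]1O[C@H](CO)[C@@H](O)[C@H](O)[C@H]1O)C(=O)C2`) gives -0.451

Compound 3 is second highest of the three, with compound 1 lower and compound 2 higher, and both gaps lie beyond the scatter. Next in line is compound 4 (`O=C1Cc2ccc(Cl)cc2C=C1C(=O)N[C@@H]1O[C@H](CO)[C@@H](O)[C@H](O)[C@H]1O`), which differs from compound 3 in one place (chloro in place of methyl on an aromatic carbon): chloro in place of methyl on an aromatic carbon. Among the compounds with values here, no measured pair shows this change, so the expectation rests on the structural change alone. The expected move is a number 0.09 log units higher from compound 3 to compound 4 (within the scatter) as a small rise within the scatter. For compound 4 the estimate is -0.36 with an expected range from -0.66 to -0.06 in this assay once measured.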

Compound 4, partition coefficient: -0.221
Compound 4: middle estimate off by 0.14 log units, on the low side; measured number inside the range.
By their numbers in this assay, from the lowest: compound 1; then compounds 3 and 4 (each within the scatter of the next); then compound 2.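

Chloro in place of methyl on an aromatic carbon gives in this assay a number 0.23 log units higher from compound 3 to compound 4 (within the scatter) and is the first one-place step in the series. On this read-out, the two groups are not told apart at this position on the shared core. No measurement here accounts for the step.

As far as these compounds go, whether an amine, a carboxylic acid or a longer chain on this aromatic carbon would give a step beyond the scatter remains open. So does whether chloro in place of methyl would give a similar step on another core.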